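Sulfonamide aryl swap on a chlorocoumarin imine core

The compounds below may be only part of what the source reports. "The series", "measured", "known", "first", "only" and "open" are said of these compounds alone.

Measured so far:
Compound 1 `Cc1cc(NS(=O)(=O)c2ccc(/N=C/c3c(Cl)c4ccccc4oc3=O)cc2)no1`: 12 nM
Compound 2 `Cc1ccnc(NS(=O)(=O)c2ccc(/N=C/c3c(Cl)c4ccccc4oc3=O)cc2)n1`: 31 nM
Compound 3 `CC(C)(C)c1cc(C(C)(C)C)c2oc(=O)c(/C=N/c3ccc(S(=O)(=O)Nc4nccs4)cc3)c(Cl)c2c1`: 12 nM

In a functional assay on MCF7 cells (Homo sapiens) for cytotoxicity, read by CCK-8 assay, with a stated time of 48 h (a lower number here means a stronger inhibitor, a higher number a weaker inhibitor), compound 3 sits level with compound 1 at the digits shown, the two together giving the lowest numbers of the three; compound 2 gives a number well above both. For the measured compounds named here, the one step measured on the sulfonamide nitrogen is a 2.6-fold higher number from compound 1 to compound 2 (0.41 log units; beyond the scatter), a modest loss when a 4-methylpyrimidin-2-yl group enters.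

Compound 4 `Cc1ccnc(NS(=O)(=O)c2ccc(/N=C/c3c(Cl)c4cc(C(C)(C)C)cc(C(C)(C)C)c4oc3=O)cc2)n1` applies the same entering group to compound 3: 4-methylpyrimidin-2-yl in place of 1,3-thiazol-2-yl on a sulfonamide nitrogen. The leaving group differs from that of compound 1, so the step from compound 1 to compound 2 is only a partial guide. Still, because a 2.6-fold higher number from compound 1 to compound 2 (0.41 log units; beyond the scatter) points upward, a step of similar size is expected, a 2.5-fold higher number from compound 3 to compound 4 (0.40 log units; beyond the scatter). The estimate for compound 4 in this assay is 30 nM, with a range of 14 nM to 65 nM.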

Compound 4, half-maximal inhibitory concentration: 32 nM
Beside the measured number, compound 4's estimate is 1.1-fold (0.03 log units) below it; the measured number falls inside the stated range.
By their numbers in this assay, from the lowest: compounds 1 and 3 (each within the scatter of the next); then compounds 2 and 4 (each within the scatter of the next).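

In this assay, a 2.7-fold higher number from compound 3 to compound 4 (0.43 log units; beyond the scatter) shows that 4-methylpyrimidin-2-yl on the sulfonamide nitrogen also gives a higher number on the core of compound 3, here with 1,3-thiazol-2-yl as the leaving group. With a 2.6-fold higher number from compound 1 to compound 2 (0.41 log units; beyond the scatter), the same direction now appears on two cores and from two leaving groups, and neither pair goes against it. Nothing available accounts for this direction.

As far as these compounds go, whether a pyridin-2-yl ring or an unsubstituted sulfonamide amine on this nitrogen follows the same direction stays open. So does whether the direction extends beyond these two pairs.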